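Amide variation on the alkynyl thiazole core

The compounds below may be only part of what the source reports. "The series", "measured", "known", "first", "only" and "open" are said of these compounds alone.

Measured so far:
compound 1 `O=C1NCCc2nc(C#Cc3ccccc3F)sc21`: 1500 nM
compound 2 `Fc1cccc(C#Cc2nc3c(s2)CN(C2CCC2)CC3)c1`: > 10000 nM
compound 3 `O=C(C1CC12CCC2)N1CCc2nc(C#Cc3ccccc3)sc2C1`: 3.9 nM

In an assay on HEK293 cells for positive allosteric modulation of metabotropic glutamate receptor 5 (Homo sapiens), read by FLIPR, with a stated time of 1 h (on this read-out higher numbers stand for an effect only at larger amounts of compound and lower numbers for an effect already at smaller amounts), compound 3 gives 3.9 nM, the lowest of the two numbers shown, and compound 1 at 1500 nM sits far beyond the scatter above it. For compound 2 the value > 10000 nM is a limit of the assay, not a number (the limit of > 10000 nM in this assay, at which 1 of the 3 values shown sits). Compound 4 `CC1CCCC(C(=O)N2CCc3nc(C#Cc4ccccc4)sc3C2)C1` differs from compound 3 in one place: a group of 7 heavy atoms (7 carbon; one six-membered non-aromatic ring of carbon only) in place of a group of 6 heavy atoms (6 carbon; one three-membered non-aromatic ring of carbon only, one four-membered non-aromatic ring of carbon only), on a carbonyl carbon. Going by the values given here, no comparable measured step exists, so the expected step of a 2.1-fold higher number from compound 3 to compound 4 (0.31 log units; beyond the scatter) in this assay is a small one, likely within or only just beyond the scatter. Compound 4 is therefore estimated at 8 nM, with a range from 2 nM to 40 nM.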

Compound 4, half-maximal effective concentration: 100 nM
Compound 4: the middle estimate sits 13-fold (1.10 log units) below what was measured; the measured number lies above the stated range.
By their numbers in this assay, from the lowest: compound 3; then compound 4; then compound 1. At a limit, above all of these: compound 2.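

The group on the carbonyl carbon is a sensitive position in this assay: 3-methylcyclohexyl in place of the group with a three-membered and a four-membered carbon ring gives a 26-fold higher number from compound 3 to compound 4 (1.41 log units; beyond the scatter). Both groups are carbon only, with no hydrogen-bond donors or acceptors and no net charge, so a large step occurs without any change in these counts. No measurement shown accounts for this step. Still open, on these data alone, is whether the ring or the methyl carries the step. Plain cyclohexyl or a tert-butyl group at this position would bear on that question.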